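Benzoyl in Place of Phenylsulfonyl: Expectation for Compound 3

A few compounds are considered here, and "the series" means these few. Any claim that something is new, unique, unknown or untested is made for them only; others in the source may bear on it.

Of the compounds shown here, two sharing one core have been measured. Compound 1 `CC(=O)/C(=C\c1c(-c2ccccc2)[nH]c2ccccc12)S(=O)(=O)c1ccccc1` carries an acetyl group; in a functional assay on OVCAR-8 cells (Homo sapiens) for inhibition, read by sulforhodamine B assay, with a stated time of 48 h (on this read-out lower numbers stand for stronger inhibition of growth and higher numbers for weaker inhibition of growth), compound 1 gives 2500 nM. Compound 2 `N#C/C(=C\c1c(-c2ccccc2)[nH]c2ccccc12)S(=O)(=O)c1ccccc1` carries a cyano group instead; in this assay compound 2 gives 6000 nM. Among the measured compounds shown here, the single measured step is a 2.4-fold higher number from compound 1 to compound 2 (0.38 log units; beyond the scatter). For the measured compounds named here, compound 2 therefore stands as the highest of the two numbers, with compound 1 as its only neighbour.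

Compound 3 `N#C/C(=C\c1c(-c2ccccc2)[nH]c2ccccc12)C(=O)c1ccccc1` differs from compound 2 at a different position: benzoyl in place of phenylsulfonyl on a double-bonded chain carbon bound to a double-bonded chain carbon and a triple-bonded carbon. Going by the values given here, no measured step touches this change, since the one known step concerns the acetyl-to-cyano exchange on the other chain carbon and not the phenylsulfonyl group. Nothing in the data shows how exchanging a sulfonyl for a carbonyl alters this assay numbers, so no step beyond the scatter is expected in either direction, and the estimate for compound 3 rests on the value of compound 2 alone. Compound 3 is estimated at 6000 nM, with a range from 2000 nM to 18000 nM, meaning an expected step of no change at the digits printed from compound 2 to compound 3 (within the scatter).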

Compound 3, concentration for 50% growth inhibition: 2200 nM
The estimate for compound 3 lay 2.7-fold (0.44 log units) above the measured number, and the stated range covers the measured number.
By their numbers in this assay, from the lowest: compounds 3 and 1 (each within the scatter of the next); then compound 2.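

In this assay, the group on the double-bonded chain carbon bound to a double-bonded chain carbon and a triple-bonded carbon proves to matter, as benzoyl in place of phenylsulfonyl gives a modest change beyond the scatter (a 2.7-fold lower number from compound 2 to compound 3 (0.44 log units; beyond the scatter)). Among the compounds shown here, the earlier step (a 2.4-fold higher number from compound 1 to compound 2 (0.38 log units; beyond the scatter)) concerned only the exchange of acetyl for cyano, so this is the first sign that the phenylsulfonyl group can also be exchanged with a measurable effect, and the sulfonyl sulfur is not required for the growth inhibition seen with compound 3. The compounds shown carry no measurement that accounts for this step, so the reason for the lower number remains unknown.

As far as these compounds go, what remains open is whether benzoyl in place of phenylsulfonyl would give a step of similar size and direction alongside acetyl, since this exchange is seen here only alongside the nitrile. The compounds shown also do not tell how an amide or a carboxylic acid at this place would behave, or what a methoxy group on the benzoyl ring would do.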